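Moving the Furan Attachment Point on a Nucleoside Core

This account rests on a few compounds, and the source may have more. Where it says the series, first, only, none or still open, it means among the compounds named here.

Of the compounds shown here, two built on a shared nucleoside core have been measured in a functional assay on K562 cells (Homo sapiens), read by MTT assay, with a stated time of 72 h; on this read-out lower numbers stand for stronger inhibition and higher numbers for weaker inhibition. Compound 1 `COc1ncnc2c1c(-c1ccsc1)cn2[C@@H]1O[C@H](CO)[C@@H](O)[C@H]1O` gives 3450 nM in this assay. Compound 2 `O=c1[nH]cnc2c1c(-c1ccoc1)cn2[C@@H]1O[C@H](CO)[C@@H](O)[C@H]1O` gives 14500 nM in this assay, the highest of the two numbers, and compound 1 stands at a lower number by a gap that lies beyond the usual scatter. Among the measured compounds shown here, no single-change step connects compound 1 and compound 2, so their two values can only be set side by side.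

Compound 3 `O=c1[nH]cnc2c1c(-c1ccco1)cn2[C@@H]1O[C@H](CO)[C@@H](O)[C@H]1O` is the next compound. It differs from compound 2 in one respect: furan-2-yl in place of furan-3-yl on an aromatic carbon. The same atoms are present in both, joined differently.

For the measured compounds named here, no measured step of this kind exists here, and the gap between compound 1 and compound 2 gives no guide to a swap between two furan isomers. Such a swap is expected to give a step of a 1.2-fold lower number from compound 2 to compound 3 (0.08 log units; within the scatter), with either direction possible and a fair chance of staying within the scatter. Compound 3 is expected to give 12000 nM in this assay, with a range from 4000 nM to 40000 nM.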

Compound 3, half-maximal inhibitory concentration: 17800 nM
Estimate against measurement, compound 3: 1.5-fold (0.17 log units) below; the measured number falls inside the stated range.
By their numbers in this assay, from the lowest: compound 1; then compounds 2 and 3 (each within the scatter of the next).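

Moving the attachment point of the furan ring, with furan-2-yl in place of furan-3-yl, gives a 1.2-fold higher number from compound 2 to compound 3 (0.09 log units; within the scatter) in this assay, so this read-out does not separate the two isomers. Among the compounds shown here, this is the first single-change comparison, and it concerns an aromatic carbon two ring bonds from the ring nitrogen: at this position, joining the same atoms differently leaves the number within the usual scatter. Nothing here offers an independent measurement that would help interpret this result.

From the compounds shown here alone, this pair covers only a swap between two furan isomers, so it remains open whether a different kind of group on the same carbon, such as an amine, a carboxylic acid or a longer chain, would move the number beyond the scatter. Going by these compounds, it also remains open whether the furan attachment point would matter as little on the core of compound 1, which gives the lower value of 3450 nM but differs from compound 2 in more than one place.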